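Cyclopropyl in Place of Propyl: What to Expect

The compounds below may be only part of what the source reports. "The series", "measured", "known", "first", "only" and "open" are said of these compounds alone.

Compound 1 `CCCCc1nc2ccccc2n1Cc1cc(Cl)c(O)c(Cl)c1`: 63.1 nM
Compound 2 `CCCCc1nc2ncccc2n1Cc1cc(Cl)c(O)c(Cl)c1`: 398 nM
Compound 3 `CCCc1nc2ncccc2n1Cc1cc(Cl)c(O)c(Cl)c1`: 794 nM

In a functional assay (aorta) with Oryctolagus cuniculus as the target (a higher number here means weaker binding, a lower number tighter binding), compound 3 gives 794 nM, the highest of the three numbers. Its nearest neighbour is compound 2, and the step of a 2.0-fold higher number from compound 2 to compound 3 (0.30 log units; within the scatter) lies within the scatter. Going by the values given here, compound 1 sits much further away, a gap that is beyond the scatter, but the two compounds differ in the core and no single step joins them to compound 3.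

Compound 4 `Oc1c(Cl)cc(Cn2c(C3CC3)nc3ncccc32)cc1Cl` is still unmeasured. It differs from compound 3 by cyclopropyl in place of propyl on an aromatic carbon. The groups that leave and enter carry the same count of heavy atoms, and neither adds donors, acceptors or charge; the difference is that a chain is replaced by a three-membered ring.

Among the compounds with values here, only one measured step touches the group on that aromatic carbon: the shortening of the chain in a 2.0-fold higher number from compound 2 to compound 3 (0.30 log units; within the scatter), which was small and within the scatter. Within the data shown here, no step shows a ring in that place. The expectation for compound 4 is therefore a step of about a 1.0-fold higher number from compound 3 to compound 4 (0.00 log units; within the scatter), no larger than the scatter, in either direction. Compound 4 is estimated at 800 nM, with a range from 300 nM to 2500 nM.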

Compound 4, dissociation constant: 631 nM
The estimate for compound 4 lay 1.3-fold (0.10 log units) above the measured number; the measured number falls inside the stated range.
By their numbers in this assay, from the lowest: compound 1; then compounds 2, 4 and 3 (each within the scatter of the next).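

In this assay, replacing the chain with a ring at this position gives a 1.3-fold lower number from compound 3 to compound 4 (0.10 log units; within the scatter), so cyclopropyl, the first ring seen on this aromatic carbon, cannot be told apart from propyl, which carries the same count of heavy atoms. The comparison with the longer chain reads the same way: cyclopropyl in place of butyl gives a 1.6-fold higher number from compound 2 to compound 4 (0.20 log units; within the scatter), which means that on this shared core the assay does not separate butyl, propyl and cyclopropyl, and a ring is accepted here as readily as an open chain. No evidence at hand accounts for this flat response, and these numbers alone offer no explanation of it.

Still open, from the compounds shown here alone, is whether any group at this position would move the number beyond the scatter, for instance an amine, a carboxylic acid, a larger ring such as cyclohexyl or a longer chain such as hexyl. Also open, going by these compounds, is whether cyclopropyl and butyl would prove equally hard to separate on the core of compound 1, which gives 63.1 nM with butyl.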